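Swapping a Pyridinyloxy Group for a Direct Pyridinyl Link

The compounds below may be only part of what the source reports. "The series", "measured", "known", "first", "only" and "open" are said of these compounds alone.

Of the compounds shown here, three have been tested in an ADME assay on MT2 cells (Homo sapiens) for cytotoxicity, read by MTT assay; on this read-out higher numbers stand for lower toxicity in this test and lower numbers for higher toxicity in this test. Compound 1 `Fc1cccc(F)c1Cc1cnc(Nc2ccc(Oc3ccncc3)c(Cl)c2)o1` gives 21000 nM. Compound 2 `Fc1cccc(F)c1Cc1cnc(Nc2ccc(Oc3ccncc3)cc2)o1`, which keeps the same core but carries hydrogen in place of chloro on an aromatic carbon, gives 21000 nM; the step of no change at the digits printed from compound 1 to compound 2 (within the scatter) shows no change within the scatter. Compound 3 `Clc1cccc(Cl)c1Cc1nnc(Nc2ccc(COCc3cccnc3)cc2)o1` differs in both its core and its connecting chain from the other two measured compounds; in this assay compound 3 gives 81000 nM, the highest of the three numbers. Compound 1 thus stands level with compound 2, the two together holding the lowest number, with compound 3 well above them.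

Compound 4 `Fc1cccc(F)c1Cc1cnc(Nc2ccc(-c3cccnc3)c(Cl)c2)o1` has not yet been tested. It differs from compound 1 in one place: pyridin-3-yl in place of (pyridin-4-yl)oxy on an aromatic carbon. The pyridine ring now attaches directly to the aromatic carbon rather than through an oxygen. Going by the values given here, none of the measured steps touches this part of the molecule: the only single-point step concerns the chloro group and shows no change, and compound 3 differs in too many places for its value to bear on the question. Among the compounds with values here, with no relevant step to draw on, the change is expected to bring no shift beyond the scatter, and the estimated step is no change at the digits printed from compound 1 to compound 4 (within the scatter). Compound 4 is therefore expected to give about 21000 nM, within a range from 8000 nM to 55000 nM.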

Compound 4, half-maximal cytotoxic concentration: 8900 nM
The estimate for compound 4 lay 2.4-fold (0.37 log units) above the measured number; low and high end bracket the measured number.
By their numbers in this assay, from the lowest: compound 4; then compounds 1 and 2 (each within the scatter of the next); then compound 3.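

Moving from an oxygen-linked pyridine to a directly attached one gives a 2.4-fold lower number from compound 1 to compound 4 (0.37 log units; beyond the scatter) in this assay, and in this test the lower number stands for higher toxicity. Going by these compounds alone, this is the first change to move the number beyond the scatter, and it lies on the aromatic carbon para to a large group, whereas the step of no change at the digits printed from compound 1 to compound 2 (within the scatter) shows that removing the chloro group on the same ring has no such effect, so this position, at least in this pair, can alter the read-out even though the shift is modest. Nothing available explains why the number falls with this change, and the pair shows only that it does.

The swap changes two things at once, the oxygen link and the point of attachment on the pyridine, so the compounds shown cannot say which of the two matters, and a directly attached pyridin-4-yl or a (pyridin-3-yl)oxy group would be needed to pull them apart. As far as these compounds go, it also remains open whether a group without a ring nitrogen, such as phenyl, or a longer chain at this position would move the number further in either direction.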